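Swapping Ethoxy for Trifluoromethyl: An Expected Read-out

A few compounds are considered here, and "the series" means these few. Any claim that something is new, unique, unknown or untested is made for them only; others in the source may bear on it.

Compound 1, `Cc1ccc2nc(C(=O)Nc3c(F)cc(-c4cccc(F)c4)cc3F)c(C)c(C(=O)O)c2c1`, gives 35.6% in a functional assay on Hep 3B2 cells (Homo sapiens) for antiproliferative activity, read by MTT assay, with a stated time of 24 h, tested at 11.11 ug/mL; on this read-out lower numbers stand for a weaker effect and higher numbers for a stronger effect at the one concentration tested.
Compound 2, `CCc1ccc2nc(C(=O)Nc3c(F)cc(-c4cccc(F)c4)cc3F)c(C)c(C(=O)O)c2c1`, gives 27.2% in this assay.
Compound 3, `CCOc1ccc2nc(C(=O)Nc3c(F)cc(-c4cccc(F)c4)cc3F)c(C)c(C(=O)O)c2c1`, gives 33.2% in this assay.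

Compound 3 stands second highest of these three numbers. Its nearest neighbour is compound 1, and the step of a number 2.4 percentage points lower from compound 1 to compound 3 (within the scatter) lies within the scatter; its furthest is compound 2, and the step of a number 6 percentage points higher from compound 2 to compound 3 (within the scatter) also lies within the scatter. Compound 4, `Cc1c(C(=O)Nc2c(F)cc(-c3cccc(F)c3)cc2F)nc2ccc(C(F)(F)F)cc2c1C(=O)O`, has not yet been measured. It differs from compound 3 by trifluoromethyl in place of ethoxy on an aromatic carbon.

The measured steps that bear on this change are the ones that altered the same part of the shared core: a number 8.4 percentage points lower from compound 1 to compound 2 (within the scatter), a number 2.4 percentage points lower from compound 1 to compound 3 (within the scatter) and a number 6 percentage points higher from compound 2 to compound 3 (within the scatter). Each of them exchanged one small group for another without moving the number beyond the scatter. None of them introduced a trifluoromethyl, so nothing measured speaks directly to this group. The expected step is therefore a number 1.2 percentage points lower from compound 3 to compound 4 (within the scatter), meaning no movement beyond the scatter. Compound 4 is estimated at 32%, with a range from 18% to 46%.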

Compound 4, a percentage reported as inhibition, at one concentration (the size of the read-out at that concentration, not a potency): 31.2%
Compound 4: middle estimate off by 0.8 percentage points, on the high side, and the stated range covers the measured number.
By their numbers in this assay, from the lowest: compounds 2, 4, 3 and 1 (each within the scatter of the next).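

In this assay the exchange of ethoxy for trifluoromethyl gives a number 2 percentage points lower from compound 3 to compound 4 (within the scatter) and so shows that this position can lose the hydrogen-bond acceptor counted for ethoxy and take on three fluorine atoms without the number moving beyond the scatter. Set against the two simple carbon groups, trifluoromethyl gives a number 4 percentage points higher from compound 2 to compound 4 (within the scatter) when it replaces ethyl and a number 4.4 percentage points lower from compound 1 to compound 4 (within the scatter) when it replaces methyl. Methyl, ethyl, ethoxy and trifluoromethyl on this aromatic carbon therefore all give numbers within the scatter of one another, and no compound among the four stands apart.

The compounds shown leave open whether an amine, a carboxylic acid or a longer chain such as butyl at this position would move the number beyond the scatter. No measurement offered here explains why these four groups read alike.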